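The source may hold more compounds than are shown below. What is called first, only, known or untested is meant among the compounds shown, and "the series" means these compounds.

Measured in a functional assay on the whole organism for inhibition, with Mus musculus as the target; on this read-out lower numbers stand for an effect already at smaller amounts and higher numbers for an effect only at larger amounts of compound:

compound 1, `CCOC(=O)Nc1cccc2c1CN(C)CC2c1ccccc1`: about 4 mg/kg
compound 2, `CCCCOC(=O)Nc1cccc2c1CN(C)CC2c1ccccc1`: 2.6 mg/kg
compound 3, `CCNCC(=O)Nc1cccc2c1CN(C)CC2c1ccc(Cl)cc1`: 6.4 mg/kg

Compound 2 differs from compound 1 by one change, (ethyl in place of hydrogen on a saturated chain carbon, two bonds along the chain from an oxygen next to a carbonyl group), and this step gave a 1.5-fold lower number from compound 1 to compound 2 (0.19 log units; within the scatter). Compound 4, `CCCCNCC(=O)Nc1cccc2c1CN(C)CC2c1ccc(Cl)cc1`, has not been measured yet. It differs from compound 3 by ethyl in place of hydrogen on a saturated chain carbon, two bonds along the chain from an amine nitrogen. This is the same kind of change as the earlier one, but not the same: there the ethyl enters two bonds along the chain from an oxygen next to a carbonyl group, here two bonds along the chain from an amine nitrogen. The difference between the cores of compound 1 and compound 3 is not broken down here. Since compound 3 is the starting point, the step from compound 3 to compound 4 is expected to be about a 1.4-fold lower number from compound 3 to compound 4 (0.15 log units; within the scatter), resting on the earlier step of a 1.5-fold lower number from compound 1 to compound 2 (0.19 log units; within the scatter). Compound 4 is therefore estimated at 4.5 mg/kg, likely between 2 mg/kg and 10 mg/kg.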

Compound 4, dose for half-maximal effect: 3.9 mg/kg
For compound 4 the middle estimate is 1.2-fold (0.06 log units) above the measured one; the measured number falls inside the stated range.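

In this assay, going from ethylamino to butylamino gives a 1.6-fold lower number from compound 3 to compound 4 (0.22 log units; within the scatter). Set beside the same lengthening of the chain on the other core, the two steps agree: the same change on two cores in this assay, a 1.5-fold lower number (0.19 log units; within the scatter) from compound 1 to compound 2 and a 1.6-fold lower number (0.22 log units; within the scatter) from compound 3 to compound 4, 1.1-fold (0.03 log units) apart, within the scatter of two such steps

So on these two cores the change carries over with a similar size, but each step on its own lies within the scatter, and neither shows that the longer chain truly changes the dose needed. Two cores are also too few to establish a rule for the whole series.

Open, from the compounds shown here alone, is whether a longer chain, such as hexyl, would move the number beyond the scatter on either core. Also open, going by these compounds, is how a branched chain or a ring on the amine nitrogen would compare.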